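The compounds below may be only part of what the source reports. "The series", "measured", "known", "first", "only" and "open" are said of these compounds alone.

Measured so far:
Compound 1 `Cn1cccc1C(=O)/C=C/c1ccc2c(c1)B(O)OC2`: in a toxicity assay on MCF-10A cells (Homo sapiens) for cytotoxicity, read by MTT assay, with a stated time of 48 h (on this read-out lower numbers stand for stronger inhibition and higher numbers for weaker inhibition), compound 1 reports only a limit, > 100000 nM.
Compound 2 `O=C(/C=C/c1ccc2c(c1)B(O)OC2)c1cccc(F)c1`: in this assay compound 2 gives 15800 nM.

Within the data shown here, compound 2 thus stands as the only numeric value in this assay; the other value recorded is a limit, (the limit of > 100000 nM in this assay, at which 1 of the 2 values shown sits). Among the measured compounds shown here, the single measured step, an at least 6.3-fold lower number from compound 1 to compound 2 (0.80 log units; beyond the scatter), is a floor rather than an exact size because compound 1 sits at the limit of > 100000 nM in this assay, at which 1 of the 2 values shown sits. Compound 3 `O=C(/C=C/c1ccc2c(c1)B(O)OC2)c1cccc(O)c1` differs from compound 2 by hydroxy in place of fluoro on an aromatic carbon. For the measured compounds named here, no measured step touches the same place, so the swap of fluoro for hydroxy has no direct precedent here; the one known step concerns the group on the carbonyl carbon, not a substituent on the 3-fluorophenyl. The step of a 1.3-fold higher number from compound 2 to compound 3 (0.10 log units; within the scatter) is therefore expected to fall within the scatter. The estimate for compound 3 in this assay is 20000 nM, with a range from 7000 nM to 60000 nM.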

Compound 3, half-maximal inhibitory concentration: 25300 nM
Compound 3: middle estimate off by 1.3-fold (0.10 log units), on the low side, within the range that was stated.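

In this assay, the swap at this position, on an aromatic carbon meta to a large group, gives a 1.6-fold higher number from compound 2 to compound 3 (0.20 log units; within the scatter), so the hydrogen-bond donor and acceptor that hydroxy brings and fluoro lacks leave the number within the scatter. With 3-hydroxyphenyl in place of 1-methyl-1H-pyrrol-2-yl on the carbonyl carbon, the result is an at least 3.9-fold lower number from compound 1 to compound 3 (0.59 log units; beyond the scatter), which shows that the step beyond the scatter seen with 3-fluorophenyl also holds with a second phenyl group. Compound 1 reports only a limit, so this step is a floor and not an exact size: the limit of > 100000 nM in this assay, at which 1 of the 3 values shown sits.

The compounds shown leave open whether an amine, a carboxylic acid or a methoxy group in this place would also stay within the scatter of compound 2. They also leave open how a plain phenyl group without either substituent would compare.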